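The compounds below may be only part of what the source reports. "The series", "measured", "known", "first", "only" and "open" are said of these compounds alone.

Of the compounds shown here, three have so far been measured in an assay on isolated protein (Cavia porcellus) with Sigma non-opioid intracellular receptor 1 (Homo sapiens) as the target, read by radioligand binding; a higher number here means a weaker inhibitor, a lower number a stronger inhibitor. Compound 1 `O=c1cc(-c2ccccc2)oc2cccc(OCCCCN3CCC(O)CC3)c12` gives 58 nM. Compound 2 `CN(C)CCCCOc1ccc2oc(-c3ccccc3)cc(=O)c2c1` gives 720 nM, and compound 3 `CN(C)CCCCCCCCCCOc1ccc2oc(-c3ccccc3)cc(=O)c2c1` gives 297 nM. Compound 3 thus stands second highest of the three numbers; its nearest neighbour is compound 2, whose value is higher, and furthest from it lies compound 1, whose value is lower. Among the compounds with values here, the only step between compounds that differ in a single place is a 2.4-fold lower number from compound 2 to compound 3 (0.38 log units; beyond the scatter), a modest change that came with the longer chain.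

Compound 4 `O=c1cc(-c2ccccc2)oc2ccc(OCCCCCCN3CCNCC3c3ncccn3)cc12` has not yet been measured. It differs from compound 3 as follows: 2-(pyrimidin-2-yl)piperazin-1-yl in place of 4-(dimethylamino)butyl on a saturated chain carbon, six bonds along the chain from an oxygen on an aromatic ring. Within the data shown here, no measured step covers a change of this kind, since compound 1, the only compound carrying a ring on its chain, differs from compound 3 in more than one place. The values of compound 1 and compound 3 alone show that a ring-bearing chain can go with a lower number, so for compound 4 a lower number in this assay is expected, a step of a 3.0-fold lower number from compound 3 to compound 4 (0.47 log units; beyond the scatter). Compound 4 is therefore estimated at 100 nM, with a range from 25 nM to 400 nM.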

Compound 4, half-maximal inhibitory concentration: 1630 nM
Estimate against measurement, compound 4: 16-fold (1.21 log units) below, outside the stated range (above it).
By their numbers in this assay, from the lowest: compound 1; then compound 3; then compound 2; then compound 4.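

In this assay, putting 2-(pyrimidin-2-yl)piperazin-1-yl in place of 4-(dimethylamino)butyl on a saturated chain carbon, six bonds along the chain from an oxygen on an aromatic ring, brings a 5.5-fold higher number from compound 3 to compound 4 (0.74 log units; beyond the scatter). This change at the chain end runs opposite in direction to a 2.4-fold lower number from compound 2 to compound 3 (0.38 log units; beyond the scatter), and it shows that a group carrying rings at this place does not by itself go with a lower number. The data give no measured explanation for this rise in the number.

The entering group changes both rings at once, so the compounds shown cannot separate the contribution of the piperazine ring from that of the pyrimidine ring. Also open, on these data alone, is how a plain piperazin-1-yl, or a morpholine, would read at this place on the same chain.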